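The compounds below may be only part of what the source reports. "The series", "measured", "known", "first", "only" and "open" are said of these compounds alone.

The series is examined in an ADME assay (liver) for pharmacokinetics, with Liver microsome (Rattus norvegicus) as the target, read by LC-MS, using microsomes, tested at 2 uM; a lower number here means slower removal, a higher number faster removal of the compound. Compound 1 `O=C(N[C@@H]1CCCC[C@H]1O)c1cnc(OC2CCCC2)c(-c2cc(C(F)(F)F)ccc2Cl)c1` gives 0.367 mL/min/kg in this assay, compound 2 `O=C(N[C@@H]1CCCC[C@H]1O)c1cnc(OC2CCC2)c(-c2ccc(Cl)cc2)c1` gives 0.21 mL/min/kg, and compound 3 `C[C@](O)(CNC(=O)c1cnc(OCC2CC2)c(-c2ccc(Cl)cc2)c1)C1CC1` gives 0.0024 mL/min/kg. Among these three numbers compound 2 stands second highest: its number and that of compound 1 lie within the usual scatter of each other, whereas the number of compound 3 lies far lower, well beyond that scatter.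

The step under study leads from compound 2 to compound 4 `CN(CC1CC1)c1ncc(C(=O)N[C@@H]2CCCC[C@H]2O)cc1-c1ccc(Cl)cc1`, which has not yet been measured in this assay. The change is (cyclopropylmethyl)(methyl)amino in place of cyclobutyloxy on an aromatic carbon, on an aromatic carbon of a six-membered aromatic ring with one nitrogen, next to the ring nitrogen and ortho to the 4-chlorophenyl group. Within the data shown here, no measured pair in the set shows this exchange, so there is no direct precedent for its effect. Compound 4 is expected to give 0.3 mL/min/kg in this assay, within a range of 0.1 mL/min/kg to 1 mL/min/kg, which means an estimated step of a 1.4-fold higher number from compound 2 to compound 4 (0.15 log units; within the scatter), a small upward shift that is not expected to lie clearly beyond the scatter.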

Compound 4, clearance: 1.73 mL/min/kg
Compound 4: middle estimate off by 5.8-fold (0.76 log units), on the low side, and the stated range ends below it.
By their numbers in this assay, from the lowest: compound 3; then compounds 2 and 1 (each within the scatter of the next); then compound 4.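

In this assay, putting (cyclopropylmethyl)(methyl)amino in place of cyclobutyloxy on this aromatic carbon, next to the ring nitrogen, gives an 8.2-fold higher number from compound 2 to compound 4 (0.92 log units; beyond the scatter), with the rest of the structure unchanged. Among these compounds, this is the first single-place comparison in the set, and it shows that this position alone can move the number beyond the scatter, even though both groups count 0 hydrogen-bond donors and 1 hydrogen-bond acceptor and carry no net charge. No measurement offered here accounts for the rise.

The exchange alters the linking atom and the attached carbon group together, so the compounds shown do not separate their contributions. From the compounds shown here alone, a cyclobutylamino group at this carbon would pair the new nitrogen link with the four-membered ring of compound 2, and how it would read remains open.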